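The compounds below may be only part of what the source reports. "The series", "measured", "known", "first", "only" and "open" are said of these compounds alone.

Measured compounds:
Compound 1, `COc1cc(C2CCN(CC(N)=O)CC2)ccc1Nc1ncc2ccc(-c3ccccc3N(C)S(C)(=O)=O)n2n1`: in an in vitro ADME assay on microsomes from liver (Macaca mulatta) for metabolic stability, using NADPH, with a stated time of 10 min, tested at 0.5 uM (on this read-out higher numbers stand for a longer-lived compound and lower numbers for a shorter-lived compound), compound 1 gives < 0.0834 h, which is a limit of the assay rather than a number.
Compound 2, `COc1cc(C2CCN(CC(N)=O)CC2)ccc1Nc1ncc2c(O)cc(-c3ccccc3N(C)S(C)(=O)=O)n2n1`: compound 2 gives < 0.0834 h, again a limit.
Compound 3, `COc1cc(C2CCN(CC(N)=O)CC2)ccc1Nc1ncc2c(C)cc(-c3ccccc3N(C)S(C)(=O)=O)n2n1`: compound 3 gives 0.1 h.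

Going by the values given here, compound 3 therefore holds the only actual number among the three values; the other two sit at the limit of < 0.0834 h in this assay, at which 2 of the 3 values shown sit. The steps that lead to compound 3 are both small: an at least 1.1-fold higher number from compound 1 to compound 3 (0.07 log units; that floor lies within the scatter) and an at least 1.1-fold higher number from compound 2 to compound 3 (0.07 log units; that floor lies within the scatter), and both have floors that lie within the usual scatter of this kind of measurement.

Compound 4, `COc1cc(C2CCN(CC(N)=O)CC2)ccc1Nc1ncc2c(Cl)cc(-c3ccccc3N(C)S(C)(=O)=O)n2n1`, differs from compound 3 by one change: chloro in place of methyl on an aromatic carbon. Among the compounds with values here, no measured step exchanges methyl for chloro, so the measured steps bear on it only in that they touch the same aromatic carbon and all stayed small. A step beyond the scatter in this assay is therefore not expected, in either direction. The estimate for compound 4 is 0.1 h, spanning 0.05 h to 0.25 h, which is expected to mean a step of no change at the digits printed from compound 3 to compound 4 (within the scatter).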

Compound 4, half-life: 0.25 h
The estimate for compound 4 lay 2.5-fold (0.40 log units) below the measured number, and the stated range covers the measured number.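

In this assay, going by these compounds alone, chloro on this aromatic carbon gives the first step at this position that is readable as beyond the scatter: a 2.5-fold higher number from compound 3 to compound 4 (0.40 log units; beyond the scatter). Compound 4 also stands clear of the two other compounds, with an at least 2.9-fold higher number from compound 2 to compound 4 (0.47 log units; beyond the scatter) and an at least 2.9-fold higher number from compound 1 to compound 4 (0.47 log units; beyond the scatter), so it is the longest-lived of the four. These last two sizes are floors and not exact sizes, and the true steps cannot be read from them: the limit of < 0.0834 h in this assay, at which 2 of the 4 values shown sit.

The compounds shown leave open whether this rise belongs to chloro alone or would also come with fluoro, bromo or a nitrile on the same carbon. They also do not tell why chloro and methyl differ here, or whether the same exchange would give a similar step with other parts of the molecule changed.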